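A few compounds are considered here, and "the series" means these few. Any claim that something is new, unique, unknown or untested is made for them only; others in the source may bear on it.

Compound 1, `CCN(CC)CCN1CCN(C(=O)COCCN(C)S(=O)(=O)c2c(C)cc(OC)cc2C)CC1`, gives 7.8 in a functional assay on Umbilical vein for antagonist activity at B1 bradykinin receptor (Homo sapiens), using Schild analysis, with a stated time of 30 min; a higher number here means a more potent compound, by a factor of ten per unit of this negative logarithm, a lower number a less potent compound.
Compound 2, `COc1cc(C)c(S(=O)(=O)N(C)CCOCC(=O)N2CCN(CCCN(C)C)CC2)c(C)c1`, gives 7.9 in this assay.
Compound 3, `COc1ccc(S(=O)(=O)N(C)CCOCC(=O)N(C)Cc2ccc(C3=NCCN3)cc2)c(C)c1`, gives 8.6 in this assay.

Compound 3 stands highest of the three numbers in this assay. Its nearest neighbour is compound 2, whose number is lower by a gap beyond the scatter; the furthest is compound 1, lower by a slightly larger gap, also beyond the scatter. Within the data shown here, the single step among the measured pair, a number 0.10 log units higher from compound 1 to compound 2 (within the scatter), concerns only the amine at the end of the chain and leaves the sulfonyl-bearing aryl untouched.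

Compound 4, `Cc1c(Cl)ccc(S(=O)(=O)N(C)CCOCC(=O)N(C)Cc2ccc(C3=NCCN3)cc2)c1Cl`, differs from compound 3 in exactly that aryl: 2,4-dichloro-3-methylphenyl in place of 4-methoxy-2-methylphenyl on a sulfonyl sulfur. Among the measured compounds shown here, no measured pair of compounds isolates this exchange, so nothing in the data sets its size or direction. In the absence of a comparable step, the expectation for compound 4 is a step of no change at the digits printed from compound 3 to compound 4 (within the scatter) in this assay, none beyond the scatter, and its number is estimated at 8.6, between 7.9 and 9.3.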

Compound 4, negative logarithm of the antagonist equilibrium constant: 9.1
For compound 4 the middle estimate is 0.50 log units below the measured one; measured number inside the range.
By their numbers in this assay, from the lowest: compounds 1 and 2 (each within the scatter of the next); then compound 3; then compound 4.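

In this assay the aryl on the sulfonyl sulfur, untouched by the earlier step at the end of the chain, proves able to move the number, with a number 0.50 log units higher from compound 3 to compound 4 (beyond the scatter) on exchanging 4-methoxy-2-methylphenyl for 2,4-dichloro-3-methylphenyl. The two groups have the same heavy-atom count and the same six-membered aromatic ring of carbon, so this step comes from a change of substituents and not from a larger group; the entering group also has no hydrogen-bond acceptor, where the leaving group has one. Nothing available here explains the step.

Going by these compounds, the exchange alters several substituents at once, so the share of each remains open, as does what a single chlorine or a trifluoromethyl group would give on this ring. On these data alone, whether the 2,4-dichloro-3-methylphenyl group would give a similar step with the dimethylamino chain of compound 2 also remains open.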